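Isobutyl in place of hydrogen: compound 3 to compound 4

A few compounds are considered here, and "the series" means these few. Any claim that something is new, unique, unknown or untested is made for them only; others in the source may bear on it.

Measured in a functional assay on K562 cells (Homo sapiens) for antiproliferative activity, read by MTT assay, with a stated time of 48 h; on this read-out lower numbers stand for stronger inhibition and higher numbers for weaker inhibition:
compound 1 `CC[C@@H](C)[C@H](NC(=O)c1ccc(Oc2nc3ccccc3nc2NC(C)(C)C)cc1)C(=O)OC`: 38700 nM
compound 2 `COC(=O)[C@H](CC(C)C)NC(=O)c1ccc(Oc2nc3ccccc3nc2NC(C)(C)C)cc1`: > 50000 nM, a limit
compound 3 `CC(C)(C)Nc1nc2ccccc2nc1Oc1ccc(C(=O)NCC(=O)O)cc1`: > 50000 nM, a limit

Compound 3 has no number in this assay, only the limit > 50000 nM. It stands at the limit of > 50000 nM in this assay, at which 2 of the 3 values shown sit. Compound 4 `CC(C)C[C@H](NC(=O)c1ccc(Oc2nc3ccccc3nc2NC(C)(C)C)cc1)C(=O)O` differs from compound 3 by isobutyl in place of hydrogen on a saturated chain carbon bound to an amide-type nitrogen and a carbonyl carbon.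

For the measured compounds named here, three measured steps bear on this change. They are an at least 1.2-fold higher number from compound 1 to compound 3 (0.11 log units; that floor lies within the scatter), an at least 1.2-fold higher number from compound 1 to compound 2 (0.11 log units; that floor lies within the scatter) and a step that the two limits leave unreadable from compound 2 to compound 3. None of them shows a size beyond the scatter. Compound 2, the measured compound with isobutyl at that place, gives > 50000 nM, which is also a limit. No step beyond the scatter and no direction is therefore expected in this assay, and the expected step is a number no higher from compound 3 to compound 4 (the limit leaves the size open). The estimate for compound 4 is 50000 nM, with an expected range of 25000 nM to 100000 nM.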

Compound 4, half-maximal inhibitory concentration: 42300 nM
Beside the measured number, compound 4's estimate is 1.2-fold (0.07 log units) above it, and the stated range covers the measured number.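

In this assay compound 4 gives 42300 nM, so a free carboxylic acid in this small set now has a number rather than a limit, and isobutyl in place of hydrogen on this saturated chain carbon gives an at least 1.1-fold lower number from compound 3 to compound 4 (0.07 log units; that floor lies within the scatter). Hydrogen in place of methyl on an oxygen next to a carbonyl group gives an at least 1.1-fold lower number from compound 2 to compound 4 (0.07 log units; that floor lies within the scatter), while 1-carboxy-3-methylbutyl in place of 1-(methoxycarbonyl)-2-methylbutyl gives a 1.1-fold higher number from compound 1 to compound 4 (0.04 log units; within the scatter), so none of these changes shows a size beyond the scatter. The steps from compound 2 and compound 3 stay floors because both compounds sit at a limit: the limit of > 50000 nM in this assay, at which 2 of the 4 values shown sit.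

As far as these compounds go, whether a benzyl group, a longer chain or an amine on this carbon would give a step beyond the scatter stays open. Changes in the shared core also stay open.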